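A few compounds are considered here, and "the series" means these few. Any claim that something is new, unique, unknown or untested is made for them only; others in the source may bear on it.

Compound 1, `COc1cc(-c2cc(/C=C/C(=O)c3ccc(N)cc3)[nH]n2)cc(OC)c1OC`: in a functional assay on HT-29 cells (Homo sapiens) for cytotoxicity, read by sulforhodamine B assay, with a stated time of 48 h, tested at 1 uM (on this read-out lower numbers stand for a stronger effect and higher numbers for a weaker effect at the one concentration tested), compound 1 gives 82%.
Compound 2, `COc1ccc(C(=O)/C=C/c2cc(-c3cc(OC)c(OC)c(OC)c3)n[nH]2)cc1OC`: in this assay compound 2 gives 88%.
Compound 3, `COc1ccc(-c2cc(/C=C/C(=O)c3ccc(N)cc3)[nH]n2)cc1OC`: in this assay compound 3 gives 99%.

Compound 4, `COc1cc(C(=O)/C=C/c2cc(-c3cc(OC)c(OC)c(OC)c3)n[nH]2)cc(OC)c1OC`, has not yet been measured. It differs from compound 2 by methoxy in place of hydrogen on an aromatic carbon. The same change has already been measured once: compound 1 differs from compound 3 by methoxy in place of hydrogen on an aromatic carbon, and the two descriptions of the place agree word for word, so this is the same change, not merely the same kind. That step gave a number 17 percentage points lower from compound 3 to compound 1 (beyond the scatter). How the core of compound 2 differs from the core of compound 3 is not broken down here, and between compound 1 and compound 2 the step was a number 6 percentage points higher from compound 1 to compound 2 (within the scatter).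

For the measured compounds named here, the step expected for compound 4 is a number 14 percentage points lower from compound 2 to compound 4 (beyond the scatter), because the one measured instance of this change was a number 17 percentage points lower from compound 3 to compound 1 (beyond the scatter) and the surroundings of the place are the same. A single earlier example is a thin basis, so the range is kept wide. Compound 4 is therefore estimated at 74%, expected to fall between 58% and 90%.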

Compound 4, a percentage reported as activity, at one concentration (the size of the read-out at that concentration, not a potency): 96%
The estimate for compound 4 lay 22 percentage points below the measured number, outside the stated range (above it).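

The same methoxy-for-hydrogen change does not carry over unchanged from one core to the other in this assay on the two cores: the same change on two cores in this assay, a number 17 percentage points lower (beyond the scatter) from compound 3 to compound 1 and a number 8 percentage points higher (within the scatter) from compound 2 to compound 4, 25 percentage points apart, beyond the scatter of two such steps. The new step reads a number 8 percentage points higher from compound 2 to compound 4 (within the scatter) and so shows no clear effect of the added methoxy group, which means the earlier a number 17 percentage points lower from compound 3 to compound 1 (beyond the scatter) is no safe guide to what this change does on a different core. For the compounds shown here, with only one pair on each core, this does not show which difference between the cores matters, nor which of the two steps a third core would follow.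

The compounds shown leave open whether a group other than methoxy at this place, such as ethoxy or a chlorine atom, would give a clearer step on either core. They also leave open how these compounds would behave at other concentrations, since each was tested at only one.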